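Cytotoxicity notes: furan-2-ylmethyl variant of the benzyl series

This account rests on a few compounds, and the source may have more. Where it says the series, first, only, none or still open, it means among the compounds named here.

The series shares one core; compound 1 is `CCOC(=O)C1(Cc2ccccc2)CN(c2ccccc2)Cc2nnn(Cc3ccccc3)c21`, compound 2 is `CCOC(=O)C1(Cc2ccccc2)CN(c2ccccc2)Cc2nnn(Cc3cccc(Cl)c3)c21`, and compound 3 is `CCOC(=O)C1(Cc2ccccc2)CN(c2ccccc2)Cc2nnn(Cc3ccc(Cl)cc3)c21`. In an ADME assay on HEL cells (Homo sapiens) for cytotoxicity, read by microscopy, with a stated time of 3 days (on this read-out higher numbers stand for lower toxicity in this test and lower numbers for higher toxicity in this test), compound 1 gives >= 20000 nM, which is a limit of the assay and not a number. Compound 2 gives > 100000 nM, again a limit. Compound 3 gives > 100000 nM, also a limit. Compound 3 thus stands at the limit of > 100000 nM in this assay, at which 2 of the 3 values shown sit, together with compound 2, whereas compound 1 sits at the limit of >= 20000 nM in this assay, at which 1 of the 3 values shown sits. The measured steps are a step that the two limits leave unreadable from compound 1 to compound 2, a step that the two limits leave unreadable from compound 1 to compound 3 and a step that the two limits leave unreadable from compound 2 to compound 3, and none of them has a readable size. Compound 4, `CCOC(=O)C1(Cc2ccccc2)CN(c2ccccc2)Cc2nnn(Cc3ccco3)c21`, differs from compound 3 by furan-2-yl in place of 4-chlorophenyl on a saturated chain carbon bound to an aromatic nitrogen. Going by the values given here, no measured step bears on this change, and the three values so far are limits only. The expectation is therefore that compound 4 also shows no cytotoxicity within the tested range, with an expected step of a number no higher from compound 3 to compound 4 (the limit leaves the size open) that cannot be called beyond the scatter. Compound 4 is estimated at 100000 nM, with a range from 20000 nM to 300000 nM.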

Compound 4, minimum cytotoxic concentration: 100000 nM
Compound 4: the middle estimate sits on the measured number at the digits printed; low and high end bracket the measured number.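

In this assay, going by these compounds alone, compound 4 gives 100000 nM, a number and not a limit, and the only value shown here that is not a limit. Compound 3 remains at a limit of the assay: the limit of > 100000 nM in this assay, at which 2 of the 4 values shown sit. Replacing the chlorinated aryl group on the saturated chain carbon bound to an aromatic nitrogen with furan-2-yl gives a number no higher from compound 3 to compound 4 (the limit leaves the size open) and a number no higher from compound 2 to compound 4 (the limit leaves the size open); the sizes of these steps, and the step involving compound 1, cannot be read.

On these data alone, the order of compound 1 and compound 4 stays open. Also open, as far as these compounds go, is how a pyridin-2-yl group, or a longer chain such as 2-phenylethyl in place of the benzyl group, would read in this test.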